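Estimating a ring swap on the amide-type nitrogen

A few compounds are considered here, and "the series" means these few. Any claim that something is new, unique, unknown or untested is made for them only; others in the source may bear on it.

Going by the values given here, in an ADME assay on NIH3T3 cells (Mus musculus) for cytotoxicity, read by MTT assay, with a stated time of 24 h (a higher number here means a weaker inhibitor, a lower number a stronger inhibitor), compound 1 (`O=C(CSc1nnc(COc2ccc3c(c2)CCCC3)o1)Nc1nc2ccc(Cl)cc2s1`) gives 247000 nM as the only exact number so far. For compound 2 (`CCOc1ccc2nc(NC(=O)CSc3nnc(COc4ccc5c(c4)CCCC5)o3)sc2c1`) the reading > 403000 nM is a limit of the assay. Compound 3 (`O=C(CSc1nnc(COc2ccc3c(c2)CCCC3)o1)Nc1ncc([N+](=O)[O-])s1`) has not been measured. Compared with compound 1, it carries 5-nitro-1,3-thiazol-2-yl in place of 6-chloro-1,3-benzothiazol-2-yl on an amide-type nitrogen.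

Among the compounds with values here, only one measured step bears on this change, and only loosely. Ethoxy in place of chloro on an aromatic carbon gave an at least 1.6-fold higher number from compound 1 to compound 2 (0.21 log units; that floor lies within the scatter) and that floor lies within the scatter. That step altered the group that leaves in compound 3 but did not replace it whole, so it points in no firm direction. Compound 3 is therefore expected to stay near compound 1 at 247000 nM with no step beyond the scatter, although the wider swap calls for a broad range. In numbers, the expected move is a 1.1-fold lower number from compound 1 to compound 3 (0.05 log units; within the scatter) and this is only an estimate. Compound 3 is estimated at 220000 nM with an expected range from 70000 nM to 450000 nM in this assay when it is tested.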

Compound 3, half-maximal inhibitory concentration: > 403000 nM
Compound 3 ended at the assay's limit (the forecaster's own chance of this, stated with the estimate: 40%); middle value at least 1.8-fold (0.26 log units) away from the limit.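

Where the earlier step changed one substituent on the ring, this one replaces the whole group on the amide-type nitrogen, and in this assay that swap gives an at least 1.6-fold higher number from compound 1 to compound 3 (0.21 log units; that floor lies within the scatter). So even exchanging a group with a five-membered and a six-membered aromatic ring for one with a single five-membered ring and a nitro group does not bring the number down at this position, although the floor of the step is too small to establish a real rise. The true size of the step cannot be read, because the reading for compound 3 is only a limit of the assay: the limit of > 403000 nM in this assay, at which 2 of the 3 values shown sit.

The compounds shown leave open whether any group on this nitrogen gives a number clearly lower than that of compound 1, for instance a ring carrying an amine or a carboxylic acid, or a plain alkyl chain in place of the ring. They also leave open how compound 2 and compound 3 rank against each other, and how much of the step belongs to the nitro group rather than to the loss of the six-membered ring.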